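The source may hold more compounds than are shown below. What is called first, only, known or untested is meant among the compounds shown, and "the series" means these compounds.

Measured so far in an ADME assay on HEK293 cells (Homo sapiens) for antiproliferative activity, read by MTT assay, with a stated time of 24 h; a lower number here means a stronger inhibitor, a higher number a weaker inhibitor:
- compound 1, `COc1cc(/C=C/C(=O)c2cc(-c3cc(OC)c(OC)c(OC)c3)n3nc(-c4ccccc4)cc3n2)cc(OC)c1OC`: 41000 nM
- compound 2, `COc1ccc(C(=O)/C=C/c2cc(-c3cc(OC)c(OC)c(OC)c3)n3nc(-c4ccccc4)cc3n2)cc1OC`: 81700 nM

Compound 1 gives the lowest of the two numbers recorded. Its nearest neighbour is compound 2, whose value sits higher, but the gap between the two lies within the scatter of repeated measurements, so no order between compound 1 and compound 2 can be read from these two values. Both sit in the weak range of this assay.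

The step of interest leads from compound 1 to compound 3, `COc1ccc(-c2cc(C(=O)/C=C/c3cc(OC)c(OC)c(OC)c3)nc3cc(-c4ccccc4)nn23)cc1OC`, which has not yet been measured in this assay. The change is hydrogen in place of methoxy on an aromatic carbon. Cut one bond further out, the trimethoxyphenyl of compound 1 becomes a dimethoxyphenyl in compound 3; the rest of the shared core and the enone are kept.

Going by the values given here, no step between measured compounds is available to anchor this change. Among the compounds with values here, with only two values in hand, both weak and within scatter of each other, the expectation for compound 3 is a step of no more than the scatter, with a slight lean toward a higher number. The expected step is estimated as a 1.3-fold higher number from compound 1 to compound 3 (0.13 log units; within the scatter). Compound 3 is estimated at 55000 nM, with a range from 20000 nM to 150000 nM.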

Compound 3, half-maximal inhibitory concentration: 46800 nM
Beside the measured number, compound 3's estimate is 1.2-fold (0.07 log units) above it, within the range that was stated.
By their numbers in this assay, from the lowest: compounds 1, 3 and 2 (each within the scatter of the next).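

Hydrogen in place of methoxy on this aromatic carbon, with the 3,4,5-trimethoxyphenyl becoming a 3,4-dimethoxyphenyl, gives the only single-place step in the series so far, and in this assay it reads as a 1.1-fold higher number from compound 1 to compound 3 (0.06 log units; within the scatter) in the ring attached to the shared core. At this position, then, the methoxy group can be replaced by hydrogen without a difference this read-out can resolve, and compound 1 and compound 3 both stay in the weak range of this assay. Nothing measured bears on the reason for this result.

Going by these compounds alone, still open is whether an amine, a carboxylic acid or a longer alkoxy chain on this same carbon would give a step beyond the scatter, since hydrogen and methoxy are the only two groups seen here. Also open, going by these compounds, is whether the same replacement on the trimethoxyphenyl kept on the enone of compound 3 would read the same way, as this one step speaks only for the ring on the core.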